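Urea series on the shared core: step to quinolin-8-yl

A few compounds are considered here, and "the series" means these few. Any claim that something is new, unique, unknown or untested is made for them only; others in the source may bear on it.

Measured compounds:
compound 1 `COc1ccccc1NC(=O)N1CCC(c2nc(-c3ccc4ccccc4n3)no2)CC1`, 410 nM
compound 2 `N#Cc1ccccc1NC(=O)N1CCC(c2nc(-c3ccc4ccccc4n3)no2)CC1`, 190 nM
compound 3 `O=C(NC1CCCCC1)N1CCC(c2nc(-c3ccc4ccccc4n3)no2)CC1`, 57 nM

All three were run in a functional assay on Shh Light II cells (Mus musculus) for inhibition, read by a luciferase reporter; on this read-out lower numbers stand for stronger inhibition and higher numbers for weaker inhibition. Compound 3 gives the lowest number of the three; its nearest neighbour is compound 2 and its furthest is compound 1, both steps beyond the scatter. Among the two aryl ureas, the change a 2.2-fold lower number from compound 1 to compound 2 (0.33 log units; beyond the scatter) was modest. The two steps that converge on compound 3 are larger: a 7.2-fold lower number from compound 1 to compound 3 (0.86 log units; beyond the scatter) and a 3.3-fold lower number from compound 2 to compound 3 (0.52 log units; beyond the scatter), both moving toward the lower number when cyclohexyl replaces an aryl group on the amide-type nitrogen.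

Compound 4 `O=C(Nc1cccc2cccnc12)N1CCC(c2nc(-c3ccc4ccccc4n3)no2)CC1` is not yet measured. It differs from compound 3 as follows: quinolin-8-yl in place of cyclohexyl on an amide-type nitrogen. The two steps bearing on this change run the other way, from aryl to cyclohexyl; reversing that direction in compound 4 is therefore expected to move the number back up, though quinolin-8-yl is not one of the aryl groups already measured, so the size is uncertain. The estimated step is a 2.6-fold higher number from compound 3 to compound 4 (0.42 log units; beyond the scatter). Compound 4 is expected to give about 150 nM in this assay, in a range from 50 nM to 450 nM.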

Compound 4, half-maximal inhibitory concentration: 1400 nM
Estimate against measurement, compound 4: 9.3-fold (0.97 log units) below; the measured number lies above the stated range.
By their numbers in this assay, from the lowest: compound 3; then compound 2; then compound 1; then compound 4.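

At the amide-type nitrogen, the identity of the aryl group matters more than the two earlier aryl ureas suggested: in this assay, a 3.4-fold higher number from compound 1 to compound 4 (0.53 log units; beyond the scatter) and a 7.4-fold higher number from compound 2 to compound 4 (0.87 log units; beyond the scatter), both larger than a 2.2-fold lower number from compound 1 to compound 2 (0.33 log units; beyond the scatter) among those two. Among these compounds, with a 25-fold higher number from compound 3 to compound 4 (1.39 log units; beyond the scatter), the largest step so far, the contrast between cyclohexyl and an aryl group proves strongly dependent on which aryl group is present; all three aryl ureas give higher numbers than the cyclohexyl urea, and none of the four compounds goes against this. No available data bear on what lies behind the rise with quinolin-8-yl.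

The compounds shown do not separate the contribution of the ring nitrogen in quinolin-8-yl from that of the second aromatic ring, a question that a naphthalen-1-yl urea or an unsubstituted phenyl urea would address. From the compounds shown here alone, it also remains open whether the low number of compound 3 is specific to cyclohexyl or extends to other saturated groups such as cyclopentyl, cycloheptyl or tetrahydropyran-4-yl.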